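Exchanging the Terminal Group on a Shared Carbonyl

The source may hold more compounds than are shown below. What is called first, only, known or untested is meant among the compounds shown, and "the series" means these compounds.

Of the compounds shown here, two built on one shared core have been tested so far. Compound 1 `COc1cc(-c2nn(-c3cccc(NC(=O)c4cccc(C(F)(F)F)c4)c3)cc2-c2ccncc2)ccc1Cl` carries a 3-(trifluoromethyl)phenyl on its carbonyl carbon; in a functional assay on SF-295 cells (Homo sapiens) for inhibition, read by sulforhodamine B assay, with a stated time of 48 h (on this read-out lower numbers stand for stronger inhibition of growth and higher numbers for weaker inhibition of growth), compound 1 gives 1020 nM, the highest of the two numbers recorded. Compound 2 `O=C(Nc1cccc(-n2cc(-c3ccncc3)c(-c3ccc(Cl)c(O)c3)n2)c1)Nc1cc(C(F)(F)F)cc(C(F)(F)F)c1` differs from it in several places at once, and in this assay compound 2 gives 618 nM, which lies within the usual scatter of the value of compound 1, so the two cannot be ordered.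

Compound 3 `COc1cc(-c2nn(-c3cccc(NC(=O)Nc4ccc(Cl)c(Cl)c4)c3)cc2-c2ccncc2)ccc1Cl` is the next candidate. Relative to compound 1 it shows one change, ((3,4-dichlorophenyl)amino in place of 3-(trifluoromethyl)phenyl on a carbonyl carbon), or cut one bond further out, (3-(trifluoromethyl)phenyl)carbonyl to (3,4-dichlorophenyl)carbamoyl. Among the compounds with values here, no measured pair in this set isolates that change. Within the data shown here, the only guide is compound 2, whose value of 618 nM sits close to that of compound 1 despite its wider differences. The step from compound 1 to compound 3 is therefore expected to be small, a 1.6-fold lower number from compound 1 to compound 3 (0.20 log units; within the scatter), at most a modest move toward stronger inhibition that may not clear the scatter. Compound 3 is accordingly estimated at 650 nM, with a likely range from 250 nM to 1700 nM.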

Compound 3, concentration for 50% growth inhibition: 691 nM
Beside the measured number, compound 3's estimate is 1.1-fold (0.03 log units) below it, within the range that was stated.
By their numbers in this assay, from the lowest: compounds 2, 3 and 1 (each within the scatter of the next).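

Within the data shown here, this is the first comparison in the set that differs in one place only: with (3,4-dichlorophenyl)amino in place of 3-(trifluoromethyl)phenyl on a carbonyl carbon whose other neighbour is an amide-type nitrogen, this assay records a 1.5-fold lower number from compound 1 to compound 3 (0.17 log units; within the scatter), so the two compounds cannot be ordered. At this position, then, the exchange brings in a nitrogen and a hydrogen-bond donor and replaces the trifluoromethyl-bearing ring with a dichlorinated one, yet it gives no difference that this read-out can separate from repeat variation. No measurement shown here offers an explanation for how close the two values lie.

From the compounds shown here alone, both terminal groups compared at this position end in a substituted phenyl ring, so the effect of a non-aromatic group, such as a cyclohexylamino group or a morpholine, remains open. Compound 2 differs from the others in several places at once, which leaves the separate contributions of its two trifluoromethyl groups and its hydroxyl group unresolved.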